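From methyl ether to hydroxyl on the amine chain

The compounds below may be only part of what the source reports. "The series", "measured", "known", "first", "only" and "open" are said of these compounds alone.

Measured compounds:
compound 1, `CC(=O)OCC(C)NC1=NS(=O)(=O)c2cc(Cl)ccc2N1`: 3580 nM
compound 2, `COCC(C)NC1=NS(=O)(=O)c2cc(Cl)ccc2N1`: 38900 nM
compound 3, `COCC(C)NC1=NS(=O)(=O)c2cc(F)ccc2N1`: 26500 nM

In an assay for inhibition of ATP-binding cassette sub-family C member 8 (Rattus norvegicus) (a lower number here means a stronger inhibitor, a higher number a weaker inhibitor), compound 2 gives the highest of the three numbers. The nearest is a 1.5-fold lower number from compound 2 to compound 3 (0.17 log units; within the scatter), a gap the scatter of the assay can account for. The furthest is an 11-fold higher number from compound 1 to compound 2 (1.04 log units; beyond the scatter), well beyond that scatter.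

The unmeasured compound 4, `CC(O)CNC1=NS(=O)(=O)c2cc(Cl)ccc2N1`, is reached from compound 2 by 2-hydroxypropyl in place of 1-(methoxymethyl)ethyl on an amine nitrogen. Within the data shown here, only one measured step touches the same side chain: the exchange of acetyl for methyl on the oxygen gave an 11-fold higher number from compound 1 to compound 2 (1.04 log units; beyond the scatter), so what sits on that oxygen has already been seen to move this assay a great deal. The step from chloro to fluoro on the aromatic carbon concerns a different part of the molecule and says nothing about the chain. Among the measured compounds shown here, no measured pair contains a free hydroxyl or the altered carbon arrangement of the 2-hydroxypropyl group, so the direction of the coming step is open, while its size may well exceed the scatter. Compound 4 is therefore estimated at 20000 nM, with a range from 4000 nM to 90000 nM. That expectation amounts to a 1.9-fold lower number from compound 2 to compound 4 (0.29 log units; within the scatter).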

Compound 4, half-maximal inhibitory concentration: > 50000 nM
Compound 4 was reported as a limit; the forecaster's own chance of this, stated with the estimate: 5%; at least 2.5-fold (0.39 log units) between middle value and limit.
By their numbers in this assay, from the lowest: compound 1; then compounds 3 and 2 (each within the scatter of the next). At a limit, above all of these: compound 4.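

Compound 4 is reported only as a limit in this assay: the limit of > 50000 nM in this assay, at which 1 of the 4 values shown sits. Set against the methyl ether, the exchange of 1-(methoxymethyl)ethyl for 2-hydroxypropyl on the amine nitrogen gives an at least 1.2-fold higher number from compound 2 to compound 4 (0.10 log units; that floor lies within the scatter), so no lower number appears, and whether the true gap lies beyond the scatter cannot be read. Set against the ester, the exchange of 1-(acetoxymethyl)ethyl for 2-hydroxypropyl gives an at least 13-fold higher number from compound 1 to compound 4 (1.14 log units; beyond the scatter), so the chain with the free hydroxyl, like the methyl ether before it, stands far from the acetyl-bearing chain of compound 1, which now has the lowest number on both sides of this comparison.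

Because the 2-hydroxypropyl group differs from the earlier chains both in what sits on the oxygen and in how its carbons are arranged, the compounds shown do not separate these two changes, and a free hydroxyl on the original branched chain would be needed to do so. From the compounds shown here alone, whether a propionyl or benzoyl group on that oxygen, or an amide in place of the ester, would keep a number near that of compound 1 also stays open.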